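Aryl Swaps on the Amine-Bound Chain Carbon

The source may hold more compounds than are shown below. What is called first, only, known or untested is meant among the compounds shown, and "the series" means these compounds.

In a functional assay on BXPC-3 cells (Homo sapiens) for inhibition, read by MTT assay, with a stated time of 72 h (a lower number here means a stronger inhibitor of growth, a higher number a weaker inhibitor of growth), compound 1 `COc1cccc(CNCCCNS(=O)(=O)c2cc(C(F)(F)F)cc(C(F)(F)F)c2)c1` gives 1700 nM, compound 2 `O=S(=O)(NCCCNCc1ccc(C(F)(F)F)cc1)c1cc(C(F)(F)F)cc(C(F)(F)F)c1` gives 1700 nM, and compound 3 `O=S(=O)(NCCCNCC1COc2ccccc2O1)c1cc(C(F)(F)F)cc(C(F)(F)F)c1` gives 1200 nM. Compound 3 thus holds the lowest of the three numbers, though a 1.4-fold lower number from compound 1 to compound 3 (0.15 log units; within the scatter) and a 1.4-fold lower number from compound 2 to compound 3 (0.15 log units; within the scatter) both sit inside the scatter, as does no change at the digits printed from compound 1 to compound 2 (within the scatter). Compound 4 `O=S(=O)(NCCCNCc1ccccc1Cl)c1cc(C(F)(F)F)cc(C(F)(F)F)c1` carries the change (2-chlorophenyl in place of 2,3-dihydro-1,4-benzodioxin-2-yl on a saturated chain carbon bound to an amine nitrogen). Every measured step in this set is an exchange at the same place, and none moved the number beyond the scatter, so no step in either direction is expected here either: a 1.3-fold higher number from compound 3 to compound 4 (0.10 log units; within the scatter) is the estimated size. Compound 4 is expected to give about 1500 nM in this assay, most likely between 700 nM and 3500 nM.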

Compound 4, concentration for 50% growth inhibition: 11000 nM
Estimate against measurement, compound 4: 7.3-fold (0.87 log units) below; measured number outside the range, above it.
By their numbers in this assay, from the lowest: compounds 3, 1 and 2 (each within the scatter of the next); then compound 4.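

Within the data shown here, this position does not tolerate every exchange in this assay: 2-chlorophenyl is the first group here to move the number beyond the scatter (a 9.2-fold higher number from compound 3 to compound 4 (0.96 log units; beyond the scatter); a 6.5-fold higher number from compound 2 to compound 4 (0.81 log units; beyond the scatter); a 6.5-fold higher number from compound 1 to compound 4 (0.81 log units; beyond the scatter)). The three earlier groups stay within the scatter of one another, so compound 4 alone stands apart. Nothing on hand bears on the cause of these steps.

Going by these compounds, it stays open whether the chlorine itself or its site on the ring carries the steps. Neither unsubstituted phenyl nor 4-chlorophenyl stands among the compounds shown at this place.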